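The compounds below may be only part of what the source reports. "The series", "measured", "known", "first", "only" and "open" are said of these compounds alone.

In a functional assay on WI-38 VA13 cells (Homo sapiens) for cytotoxicity (a lower number here means that less compound is needed, a higher number that more compound is needed for the effect), compound 1 `O=C(Nc1ccc2nc(NC(=O)C3CCC3)sc2c1)c1c(Cl)cccc1Cl` gives 0.013 ug/mL and compound 2 `O=C(Nc1nc2ccc(NC(=O)c3c(Cl)cccc3Cl)cc2s1)OCc1ccccc1` gives 0.018 ug/mL. Among the compounds with values here, the one step joining them, a 1.4-fold higher number from compound 1 to compound 2 (0.14 log units; within the scatter), leaves the two within the scatter of each other, so compound 2 stands highest of the two numbers only by position, not by any difference that counts. Compound 3 `O=C(Nc1nc2ccc(NC(=O)c3c(Cl)cccc3Cl)cc2s1)Oc1ccccc1` is compound 2 with phenyl in place of benzyl on an oxygen next to a carbonyl group. Within the data shown here, no measured step touches that oxygen, so nothing among the measured compounds speaks for or against it; the only step that exists, the exchange on the carbonyl carbon from compound 1 to compound 2, was itself within the scatter. On that basis no step beyond the scatter is expected in this assay, and compound 3 is estimated at 0.02 ug/mL, with a range from 0.007 ug/mL to 0.06 ug/mL, which means an expected step of a 1.1-fold higher number from compound 2 to compound 3 (0.05 log units; within the scatter).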

Compound 3, half-maximal effective concentration: 1.1 ug/mL
Compound 3: middle estimate off by 55-fold (1.74 log units), on the low side; the whole stated range lies below it.
By their numbers in this assay, from the lowest: compounds 1 and 2 (each within the scatter of the next); then compound 3.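

In this assay, the oxygen next to a carbonyl group proves sensitive to what it carries: phenyl in place of benzyl gives a 61-fold higher number from compound 2 to compound 3 (1.79 log units; beyond the scatter), although both groups hold one six-membered aromatic ring of carbon only and neither brings a hydrogen-bond donor or acceptor. The earlier exchange on the carbonyl carbon, a 1.4-fold higher number from compound 1 to compound 2 (0.14 log units; within the scatter), had shown no such sensitivity, whereas phenoxy in place of cyclobutyl on that carbon gives an 85-fold higher number from compound 1 to compound 3 (1.93 log units; beyond the scatter), so among these compounds the phenoxy group alone stands apart. Nothing available accounts for this difference between benzyl and phenyl.

The compounds shown leave open how a longer chain, such as phenethyl, would behave on that oxygen. They also leave open whether an amine nitrogen in place of that oxygen would keep the low number of compound 2.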